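Moving the chlorine around the ring of a succinimide amide

The compounds below may be only part of what the source reports. "The series", "measured", "known", "first", "only" and "open" are said of these compounds alone.

Of the compounds shown here, three have been tested in a functional assay on the whole organism (strain Albino Swiss CD1) with Mus musculus as the target, in the maximal electroshock model; a higher number here means that more compound is needed for the effect, a lower number that less compound is needed. Compound 1 `CC(C(=O)NCc1cccc(Cl)c1)N1C(=O)CCC1=O` gives 82 mg/kg, compound 2 `CCC(C(=O)NCc1ccccc1)N1C(=O)CCC1=O` gives 73.3 mg/kg, and compound 3 `CCC(C(=O)NCc1ccccc1Cl)N1C(=O)CCC1=O` gives 113 mg/kg. Compound 3 holds the highest of the three numbers, but its gaps to compound 1 and compound 2 are both within the usual scatter, so no real ordering can be read from them.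

Compound 4 `CCC(C(=O)NCc1cccc(Cl)c1)N1C(=O)CCC1=O` differs from compound 3 by 3-chlorophenyl in place of 2-chlorophenyl on a saturated chain carbon bound to an amide-type nitrogen. Going by the values given here, the one measured step that touches this region is the one from compound 2 to compound 3, where a 1.5-fold higher number from compound 2 to compound 3 (0.19 log units; within the scatter); it was within the scatter. Compound 1, which also carries a 3-chlorophenyl group, sits close to compound 3 as well. On this footing no step beyond the scatter is expected in this assay, only a slight drift toward the values of compound 1 and compound 2.

Compound 4 is therefore estimated at 90 mg/kg, with a range from 55 mg/kg to 150 mg/kg, an expected step of a 1.3-fold lower number from compound 3 to compound 4 (0.10 log units; within the scatter).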

Compound 4, dose for half-maximal effect: 96.6 mg/kg
Estimate against measurement, compound 4: 1.1-fold (0.03 log units) below; the range from low to high includes it.
By their numbers in this assay, from the lowest: compounds 2, 1, 4 and 3 (each within the scatter of the next).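

Swapping 2-chlorophenyl for 3-chlorophenyl gives a 1.2-fold lower number from compound 3 to compound 4 (0.07 log units; within the scatter) in this assay and leaves the two chlorine placements indistinguishable in this assay. With the 3-chlorophenyl group in place, the two other single changes also stay small: chloro in place of hydrogen on an aromatic carbon gives a 1.3-fold higher number from compound 2 to compound 4 (0.12 log units; within the scatter) and methyl in place of hydrogen on the saturated chain carbon gives a 1.2-fold higher number from compound 1 to compound 4 (0.07 log units; within the scatter) in the same assay. Compound 4 thus shows that neither the presence of this chlorine, nor its placement, nor this added methyl separates these compounds here, and no measurement at hand says anything about the reason.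

From the compounds shown here alone, the aromatic ring carries only hydrogen or chloro in these compounds, so it remains open whether a methoxy or trifluoromethyl group there would give a step beyond the scatter. The same question stands for a longer chain or an amine on the saturated chain carbon.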